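Methyl on the Benzyl Ring of a Terpenoid Amine

A few compounds are considered here, and "the series" means these few. Any claim that something is new, unique, unknown or untested is made for them only; others in the source may bear on it.

Of the compounds shown here, two have been measured in a functional assay on BMMC cells (Mus musculus, strain C57BL/6) for inhibition, with stated times of 5 days and 48 h; on this read-out higher numbers stand for weaker inhibition and lower numbers for stronger inhibition. Compound 1, `C=C1CC[C@@H]2[C@](C)(CO)[C@H](O)CC[C@@]2(C)[C@@H]1CCC1C(=O)OC[C@H]1O`, carries a primary alcohol and a saturated lactone; in this assay compound 1 reaches only the limit of > 30000 nM, a limit of the measurement rather than a number. Compound 2, `C=C1CC[C@@H]2[C@](C)(CNCc3ccccc3)[C@H](O)CC[C@@]2(C)[C@@H]1/C=C/C1=CCOC1=O`, bears a benzylamino group and an unsaturated lactone linked through a double bond; in this assay compound 2 gives 960 nM. For the measured compounds named here, compound 2 thus stands as the only numerical value, the other being the limit described by the limit of > 30000 nM in this assay, at which 1 of the 2 values shown sits.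

Compound 3, `C=C1CC[C@@H]2[C@](C)(CNCc3ccc(C)cc3)[C@H](O)CC[C@@]2(C)[C@@H]1/C=C/C1=CCOC1=O`, differs from compound 2 by methyl in place of hydrogen on an aromatic carbon, a change from benzylamino to (4-methylbenzyl)amino. Going by the values given here, no step between measured compounds is available to calibrate so small an addition. Given that compound 2 gives 960 nM and the change adds a single carbon without donors, acceptors or charge, the step of a 1.1-fold lower number from compound 2 to compound 3 (0.03 log units; within the scatter) is expected to stay within the usual scatter of repeated measurements. Compound 3 is therefore estimated at 900 nM in this assay, with a range from 300 nM to 3000 nM.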

Compound 3, half-maximal inhibitory concentration: 740 nM
Compound 3: middle estimate off by 1.2-fold (0.09 log units), on the high side; the measured number falls inside the stated range.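

In this assay, methyl in place of hydrogen on an aromatic carbon, para to a large group, gives a 1.3-fold lower number from compound 2 to compound 3 (0.11 log units; within the scatter) and so leaves the read-out without a difference that can be told from the scatter. For the compounds shown here, this is the first step that can be read for a single change: compound 1 and compound 2 differ in more than one place, so they said nothing about the benzyl ring alone. It shows that, on this ring and at this position, a single added carbon with no donors, acceptors or charge is tolerated in the sense that the inhibition of compound 2 is kept in compound 3, and nothing measured here offers an explanation for that outcome.

What the compounds shown leave open is whether that tolerance reaches beyond methyl, for instance to a methoxy group, a chlorine atom, a carboxylic acid or a longer chain at the same place. Also open, as far as these compounds go, is whether the benzylamino nitrogen itself matters, as a comparison with a simple primary amine or an amide at that carbon would tell.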